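The source may hold more compounds than are shown below. What is called first, only, known or untested is meant among the compounds shown, and "the series" means these compounds.

Compound 1 `COc1cc(OC)c(-c2coc3cc(OCC=C(C)C)ccc3c2=O)cc1OC`: 3800 nM
Compound 2 `C=CCOc1ccc2c(=O)c(-c3cc(OC)c(OC)cc3OC)coc2c1`: > 10000 nM (a limit of the assay)

Going by the values given here, in a functional assay on HUVEC cells (Homo sapiens) for antiproliferative activity, read by MTT assay, with a stated time of 24 h (on this read-out higher numbers stand for weaker inhibition and lower numbers for stronger inhibition), compound 1 gives 3800 nM, the only true number so far. Compound 2 gives > 10000 nM, which is a limit and not a number.

Compound 3 `C#CCOc1ccc2c(=O)c(-c3cc(OC)c(OC)cc3OC)coc2c1` keeps the shared core of compound 1 and alters one group, 3-methylbut-2-en-1-yl to propargyl: ethynyl in place of 2-methylprop-1-en-1-yl on a saturated chain carbon bound to an oxygen on an aromatic ring.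

Among the compounds with values here, one measured step bears on this change, a swap at the same place with vinyl as the incoming group. It is an at least 2.6-fold higher number from compound 1 to compound 2 (0.42 log units; beyond the scatter), and its size is open-ended, as the limit of > 10000 nM in this assay, at which 1 of the 2 values shown sits, shows. Ethynyl itself has not been measured, so this comparison is only a guide. A move toward weaker inhibition in this assay is expected, and the result may also end at the limit. The expected change is a 2.4-fold higher number from compound 1 to compound 3 (0.37 log units; beyond the scatter). For compound 3 the estimated value is 9000 nM, within a range of 3000 nM to 30000 nM.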

Compound 3, half-maximal inhibitory concentration: > 10000 nM
Compound 3: a limit, no number; the forecaster's own chance of this, stated with the estimate: 50%; at least 1.1-fold (0.04 log units) between middle value and limit.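

In this assay, compound 3 shows that the loss seen with vinyl is not confined to that one group: with ethynyl at the same place, a triple bond instead of a double bond, the change is an at least 2.6-fold higher number from compound 1 to compound 3 (0.42 log units; beyond the scatter). This step is open-ended, since the value of compound 3 is a limit and not a number. Both replacements of 2-methylprop-1-en-1-yl shown here therefore give weaker inhibition than compound 1, but the step between compound 2 and compound 3 cannot be read, and vinyl and ethynyl cannot be ranked, because both values are limits: the limit of > 10000 nM in this assay, at which 2 of the 3 values shown sit.

As far as these compounds go, how far compound 2 and compound 3 truly lie from compound 1 stays unknown. Also open, from the compounds shown here alone, is whether a saturated chain such as 3-methylbutyl, a longer chain such as geranyl, or a chain ending in an amine would match or improve on compound 1 at 3800 nM.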